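This account rests on a few compounds, and the source may have more. Where it says the series, first, only, none or still open, it means among the compounds named here.

Measured in a physicochemical assay for solubility, read by HPLC, using the shake flask method, in phosphate buffer, with a stated time of 20 h, at pH 6.5; on this read-out lower numbers stand for lower solubility and higher numbers for higher solubility:
- compound 1 `CN1CCN(c2nccc3nc(-c4ccc(F)c(F)c4)[nH]c23)CC1`: 130000 nM
- compound 2 `O=C1CN(c2nccc3[nH]c(-c4ccc(F)c(F)c4)nc23)CCN1`: < 5000 nM (a limit of the assay, not a number)
- compound 3 `Fc1ccc(-c2nc3c(C4CCNCC4)nccc3[nH]2)cc1F`: 200000 nM

Going by the values given here, compound 3 and compound 1 lie within the usual scatter of each other, and they are the only two compounds here with actual numbers. The next compound to be measured is compound 4 `Fc1ccc(-c2nc3c(N4CCNCC4)nccc3[nH]2)cc1F`. It carries piperazin-1-yl in place of piperidin-4-yl on an aromatic carbon, next to the ring nitrogen: piperazin-1-yl in place of piperidin-4-yl on an aromatic carbon.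

Among the compounds with values here, one measured step bears on this place, an at least 40-fold higher number from compound 2 to compound 3 (1.60 log units; beyond the scatter). It is large and swaps 3-oxopiperazin-1-yl for piperidin-4-yl. However, its starting compound has a carbonyl in the ring, which neither compound 3 nor compound 4 has, so it is only a weak guide here. A closer guide is compound 1 at 130000 nM, which has a piperazine ring at this place, with a methyl group added.

In this assay, no step beyond the scatter is therefore expected. The estimated step is a 1.3-fold lower number from compound 3 to compound 4 (0.12 log units; within the scatter). For compound 4 the estimate is 150000 nM, with an expected range from 60000 nM to 320000 nM.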

Compound 4, solubility: 150000 nM
The estimate for compound 4 equals the measured number at the digits printed; the measured number falls inside the stated range.
By their numbers in this assay, from the lowest: compounds 1, 4 and 3 (each within the scatter of the next). At a limit, below all of these: compound 2.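

In this assay, putting piperazin-1-yl in place of piperidin-4-yl on this aromatic carbon gives a 1.3-fold lower number from compound 3 to compound 4 (0.12 log units; within the scatter), so a ring with 2 hetero atoms and a ring with 1 hetero atom cannot be told apart here. Going by these compounds alone, the second new step, an at least 30-fold higher number from compound 2 to compound 4 (1.47 log units; beyond the scatter), is a cleaner comparison than the earlier one that started from compound 2, since piperazin-1-yl and 3-oxopiperazin-1-yl differ only by the carbonyl, which isolates this one ring feature for the first time. Compound 2 stands at a limit and not at a number, so this step gives only a minimum size and the full size of the gap stays unknown: the limit of < 5000 nM in this assay, at which 1 of the 4 values shown sits.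

The compounds shown leave open whether other groups on this carbon, such as a morpholine ring, an open-chain amine or a group carrying a carboxylic acid, would stay level with compound 3 and compound 4 in this assay. On these data alone, it also remains open whether a carbonyl placed in the piperidin-4-yl ring, or in the methyl-bearing ring of compound 1, would go with a step of similar size.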